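This account rests on a few compounds, and the source may have more. Where it says the series, first, only, none or still open, it means among the compounds named here.

Working notes on the series. Compound 1 `O=C1OC(c2cnc3ccccc3c2)CN1C1CCN(Cc2cc3ccccc3[nH]2)CC1` is one of two compounds with a result in an in vitro functional assay on RBL cells for antagonist activity at C-C chemokine receptor type 8 (Homo sapiens), read by FLIPR and calcium flux; on this read-out higher numbers stand for weaker inhibition and lower numbers for stronger inhibition. In this assay compound 1 reaches only a limit of the assay, < 50200 nM, and not a number. Within the data shown here, compound 2 `COc1ccc2nccc(C3CN(C4CCN(Cc5cc6ccccc6o5)CC4)C(=O)O3)c2c1` gives the single number of the set, 1260 nM in this assay, so compound 2 stands alone among the figures. The further value, that of compound 1, is a limit, as the line the limit of < 50200 nM in this assay, at which 1 of the 2 values shown sits, records. Among the measured compounds shown here, no pair of measured compounds differs in one place, so there is no measured step to lean on.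

Compound 3 `COc1ccc2nccc(C3CN(C4CCN(C(=O)c5ccc(Cl)c(Cl)c5)CC4)C(=O)O3)c2c1` has not yet been tested. Compared with compound 2 it carries (3,4-dichlorophenyl)carbonyl in place of (1-benzofuran-2-yl)methyl on an amine nitrogen in a ring. For the measured compounds named here, with no measured step available, the size of this change in this assay has to be guessed from the structures alone. The expectation is a loss of potency beyond the scatter, a step of about a 4.0-fold higher number from compound 2 to compound 3 (0.60 log units; beyond the scatter). Compound 3 is therefore estimated at 5000 nM in this assay, within a range from 1000 nM to 30000 nM, with a real chance that only a limit is reported.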

Compound 3, half-maximal inhibitory concentration: 6310 nM
Beside the measured number, compound 3's estimate is 1.3-fold (0.10 log units) below it; measured number inside the range.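

Working notes, continued. In this assay, among these compounds, replacing (1-benzofuran-2-yl)methyl with (3,4-dichlorophenyl)carbonyl on an amine nitrogen in a ring gives the first measured step, a 5.0-fold higher number from compound 2 to compound 3 (0.70 log units; beyond the scatter), so the group at this position does change the read-out. The two groups have the same counts of heavy atoms, hydrogen-bond donors and hydrogen-bond acceptors, so those counts alone do not fix the result, and compound 3 still gives a number rather than a limit. Nothing measured here gives a cause for this step.

On these data alone, the change alters the aromatic rings, the carbonyl and the chlorine atoms all at once, so the share of each stays open; a (3,4-dichlorophenyl)methyl group or an unsubstituted phenylcarbonyl group at the same nitrogen would help to separate them. As far as these compounds go, compound 1 carries only a limit and differs from the other two compounds in more than one place, so steps to it cannot be read, and the role of the methoxy group on the shared core also remains open.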